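From a Fluoro to a Methoxy on the Benzyl Ring

The compounds below may be only part of what the source reports. "The series", "measured", "known", "first", "only" and "open" are said of these compounds alone.

Of the compounds shown here, two sharing one core have been measured in a functional assay on EKVX cells (Homo sapiens) for inhibition, read by sulforhodamine B assay, with a stated time of 48 h; a higher number here means a weaker inhibitor of growth, a lower number a stronger inhibitor of growth. Compound 1 `COc1ccc(CNc2nc3cc(N)cc(N)c3nc2-c2ccccc2)cc1OC` gives 5890 nM in this assay. Compound 2 `Nc1cc(N)c2nc(-c3ccccc3)c(NCc3ccc(F)cc3)nc2c1` gives 1910 nM in this assay. Within the data shown here, the single step between them, a 3.1-fold lower number from compound 1 to compound 2 (0.49 log units; beyond the scatter), is the only measured change, and it swaps the whole substituted benzyl pattern at once. Among the measured compounds shown here, compound 2 thus stands at the lowest of the two numbers, with compound 1 as its only neighbour.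

Compound 3 `COc1ccc(CNc2nc3cc(N)cc(N)c3nc2-c2ccccc2)cc1` differs from compound 2 by methoxy in place of fluoro on an aromatic carbon. That measured step bears on it only in part: it moved from a dimethoxy pattern to a single fluoro, whereas compound 3 carries a single methoxy, so the change sits between the two measured structures. The expected step in this assay, a 1.8-fold higher number from compound 2 to compound 3 (0.26 log units; within the scatter), is therefore towards a higher number but smaller than the step from compound 1 to compound 2. Compound 3 is estimated to give 3500 nM in this assay, within a range from 1500 nM to 8000 nM.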

Compound 3, concentration for 50% growth inhibition: 14800 nM
Compound 3: the middle estimate sits 4.2-fold (0.63 log units) below what was measured, and the stated range ends below it.
By their numbers in this assay, from the lowest: compound 2; then compound 1; then compound 3.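

In this assay, the exchange on the aromatic carbon para to a large group proves to matter on its own: methoxy in place of fluoro gives a 7.7-fold higher number from compound 2 to compound 3 (0.89 log units; beyond the scatter), a larger step than the one that swapped the whole benzyl pattern in the earlier pair. Hydrogen in place of methoxy on an aromatic carbon gives a 2.5-fold higher number from compound 1 to compound 3 (0.40 log units; beyond the scatter), so compound 3, with one methoxy, does not lie between compound 1 and compound 2, and among these three compounds the number does not simply follow the count of methoxy groups. Nothing available accounts for either step, or for the second methoxy of compound 1 going with a lower number than compound 3 shows.

These three compounds leave open where a plain unsubstituted benzyl group, or a chloro, hydroxyl or methyl group on that same aromatic carbon, would fall relative to fluoro and methoxy. As far as these compounds go, the rest of the shared core stays the same throughout, so it also remains open whether this order would hold with another group, such as a carboxylic acid or an amine, elsewhere on the molecule.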